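Aminoquinoline ethers: methoxy on the benzylamine ring

A few compounds are considered here, and "the series" means these few. Any claim that something is new, unique, unknown or untested is made for them only; others in the source may bear on it.

Measured so far:
compound 1 `CC(CNCC1CC1)Oc1cccc2ccc(N)nc12` — 80 nM
compound 2 `CC(CNCC1CCCC1)Oc1cccc2ccc(N)nc12` — 100 nM
compound 3 `CC(CNCc1ccccc1)Oc1cccc2ccc(N)nc12` — 100 nM

In an assay on cells with melanin-concentrating hormone receptor 1 (Homo sapiens) as the target, read by radioligand binding (a lower number here means a stronger inhibitor, a higher number a weaker inhibitor), compound 3 stands level with compound 2, and the two together hold the highest numbers of the three; the widest step among them is a 1.3-fold higher number from compound 1 to compound 3 (0.10 log units; within the scatter) and so lies within the scatter, as do a 1.3-fold higher number from compound 1 to compound 2 (0.10 log units; within the scatter) and no change at the digits printed from compound 2 to compound 3 (within the scatter). Compound 4 `COc1cccc(CNCC(C)Oc2cccc3ccc(N)nc23)c1` differs from compound 3 by methoxy in place of hydrogen on an aromatic carbon, placed meta to a large group; cut one bond further out, the change reads phenyl to 3-methoxyphenyl. None of the three steps touches substitution on that ring; each only swaps the ring on the amine-bound carbon, and each stayed within the scatter. No step beyond the scatter is therefore expected: compound 4 is estimated at 90 nM (range 30 nM to 300 nM), a move of a 1.1-fold lower number from compound 3 to compound 4 (0.05 log units; within the scatter) that is expected to be flat.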

Compound 4, half-maximal inhibitory concentration: 1 nM
Compound 4: the middle estimate sits 90-fold (1.95 log units) above what was measured; measured number outside the range, below it.
By their numbers in this assay, from the lowest: compound 4; then compounds 1, 2 and 3 (each within the scatter of the next).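

In this assay, methoxy in place of hydrogen on an aromatic carbon, meta to a large group, produces a large step (a 100-fold lower number from compound 3 to compound 4 (2.00 log units; beyond the scatter)), whereas the ring swaps among compound 1, compound 2 and compound 3 all stayed within the scatter. The steps that change the cyclopentyl or cyclopropyl to 3-methoxyphenyl are of similar size (a 100-fold lower number from compound 2 to compound 4 (2.00 log units; beyond the scatter); an 80-fold lower number from compound 1 to compound 4 (1.90 log units; beyond the scatter)), so in this set, the phenyl ring's substitution matters far more than the ring's identity. No measurement shown accounts for the drop.

Open, as far as these compounds go, is whether ethoxy, hydroxy or chloro on that aromatic carbon would keep so low a number, and whether methoxy on another carbon of the ring would.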